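A few compounds are considered here, and "the series" means these few. Any claim that something is new, unique, unknown or untested is made for them only; others in the source may bear on it.

Measured compounds in a functional assay on MOLT-3 cells (Homo sapiens); a higher number here means a weaker inhibitor, a lower number a stronger inhibitor:
compound 1, `CCCCCCCSC[C@H](NC(C)=O)C(=O)CCl`, gives 2500 nM
compound 2, `CCCCCCCCCSC[C@H](NC(C)=O)C(=O)CCl`, gives 6700 nM
compound 3, `CCCCCCCCCCCCCSC[C@H](NC(C)=O)C(=O)CCl`, weakest of the three

In this assay compound 3 gives only a limit of the assay, > 100000 nM. Within the data shown here, that limit, (the limit of > 100000 nM in this assay, at which 1 of the 3 values shown sits), is the one recorded value that is not a number. The next member, compound 4, `CCCCCCCCCCCCCCCCCCCCSC[C@H](NC(C)=O)C(=O)CCl`, differs from compound 3 by heptyl in place of hydrogen on a saturated chain carbon, ten or more bonds along the chain from a sulfur. Among the measured compounds shown here, the steps that bear on this are all chain extensions: a 2.7-fold higher number from compound 1 to compound 2 (0.43 log units; beyond the scatter), an at least 40-fold higher number from compound 1 to compound 3 (1.60 log units; beyond the scatter) and an at least 14-fold higher number from compound 2 to compound 3 (1.17 log units; beyond the scatter). Each longer chain gave a higher number, and the longest gave only a limit, so for compound 4 a further large rise in this assay, most likely again reported only as a limit, is expected. The estimated step is a step that the limit leaves unreadable from compound 3 to compound 4. Compound 4 is estimated at 300000 nM, range 100000 nM to 1000000 nM.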

Compound 4, half-maximal inhibitory concentration: > 100000 nM
Compound 4: no number, only a limit (the forecaster's own chance of this, stated with the estimate: 90%); the middle value lies beyond the limit too.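

In this assay compound 3 gives > 100000 nM, a limit of the assay. Among these compounds, compound 4 gives > 100000 nM, also a limit, so no step between compound 3 and compound 4 can be read. As far as these compounds go, how far either compound lies beyond that limit remains open.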